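A few compounds are considered here, and "the series" means these few. Any claim that something is new, unique, unknown or untested is made for them only; others in the source may bear on it.

Measured so far:
Compound 1, `CCCCCCc1cn(C(c2ccccc2)c2cc3cc(Br)ccc3nc2OC)nn1`, in an ADME assay on SK-OV-3 cells (Homo sapiens) for cytotoxicity, read by sulforhodamine B assay, with a stated time of 48 h, tested at 10 uM (on this read-out lower numbers stand for less inhibition and higher numbers for more inhibition at the one concentration tested (going by the name of the read-out)), gives 7.17%.
Compound 2, `CCOC(=O)c1cn(C(c2ccccc2)c2cc3cc(Br)ccc3nc2OC)nn1`, in this assay gives 2.01%.

Compound 2 has the lowest of the two numbers in this assay; the nearest is compound 1, and the step of a number 5.2 percentage points lower from compound 1 to compound 2 (within the scatter) is within the scatter, so the two values cannot be told apart. The unmeasured compound 3, `COc1nc2ccc(Br)cc2cc1C(c1ccccc1)n1cc(CO)nn1`, differs from compound 2 in one place: hydroxymethyl in place of ethoxycarbonyl on an aromatic carbon.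

Within the data shown here, only one measured step is available, a number 5.2 percentage points lower from compound 1 to compound 2 (within the scatter), and it concerns a different exchange on the same aromatic carbon; it shows that replacing one group there by another left the inhibition in this assay low and unchanged beyond the scatter. On that basis no step beyond the scatter is expected for compound 3, and the estimated step of a number 2 percentage points higher from compound 2 to compound 3 (within the scatter) is taken as small. Compound 3 is thus estimated to give 4% in this assay, with a likely range from -6% to 14%.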

Compound 3, a percentage reported as inhibition, at one concentration (the size of the read-out at that concentration, not a potency): 3.23%
Estimate against measurement, compound 3: 0.8 percentage points above; the range from low to high includes it.
By their numbers in this assay, from the lowest: compounds 2, 3 and 1 (each within the scatter of the next).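

With the step of a number 1.2 percentage points higher from compound 2 to compound 3 (within the scatter) and the step of a number 3.9 percentage points lower from compound 1 to compound 3 (within the scatter), the carbon of the five-membered aromatic ring with 3 nitrogen now carries three different groups in this assay without any pair of them being told apart. This extends the earlier comparison to hydroxymethyl, which has a hydrogen-bond donor, whereas ethoxycarbonyl has none, and that difference in the group brings no step beyond the scatter here. Nothing measured explains this flat picture.

On these data alone, all three compounds remain low at the single concentration tested, so it stays open whether any group at this carbon can move the inhibition beyond the scatter. An aminomethyl group or a carboxylic acid in that place could test this, and the shown compounds do not tell how either would read.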